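The source may hold more compounds than are shown below. What is called first, only, known or untested is meant among the compounds shown, and "the series" means these compounds.

The series was examined in a functional assay on the whole organism (strain Wistar) for inhibition, with Rattus norvegicus as the target, read by paw edema, with stated times of 30 min and 3 h, at a dose of 200 mg/kg by the oral route; on this read-out lower numbers stand for less inhibition and higher numbers for more inhibition at the one dose given (going by the name of the read-out). Compound 1, `O=C(O)c1ccc(-n2c(-c3ccccc3)cc3c2CCCC3)cc1O`, gave in this assay a read-out of 0%. Compound 2, `COc1ccccc1-c1cc2c(n1-c1ccc(O)c(C(=O)O)c1)CCCC2`, gave in this assay a read-out of 50%. Compound 3, `O=C(O)c1cc(-n2c(-c3cccc(C(F)(F)F)c3)cc3c2CCCC3)ccc1O`, gave in this assay a read-out of 20%. On these three numbers compound 2 stands highest: its nearest neighbour is compound 3, whose number lies below it by a gap beyond the usual scatter, and the furthest is compound 1, whose number lies lower still, again beyond the scatter. No two of the measured compounds differ in only one place, so no single-step comparison is available among them.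

Compound 4, `N#Cc1ccc(-c2cc3c(n2-c2ccc(O)c(C(=O)O)c2)CCCC3)cc1`, has not yet been measured. It differs from compound 2 in one place: 4-cyanophenyl in place of 2-methoxyphenyl on an aromatic carbon. For the measured compounds named here, since no measured pair shows what this kind of exchange does, any expectation rests only on the spread of the three numbers. The step from compound 2 to compound 4 is expected to be downward and larger than the scatter, namely a number 25 percentage points lower from compound 2 to compound 4 (beyond the scatter). For compound 4 the read-out in this assay is estimated at 25%, with a range from 0% to 55%.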

Compound 4, a percentage reported as inhibition, in the whole organism at one dose (the size of the read-out at that dose, not a potency): 0%
Estimate against measurement, compound 4: 25 percentage points above, and the stated range covers the measured number.
By their numbers in this assay, from the lowest: compounds 1 and 4 (each within the scatter of the next); then compound 3; then compound 2.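

In this assay, replacing 2-methoxyphenyl with 4-cyanophenyl on the aromatic carbon next to the ring nitrogen gives a number 50 percentage points lower from compound 2 to compound 4 (beyond the scatter). For the compounds shown here, this is the first comparison that changes only one place, and it shows that the group at this position can by itself make a large difference to the read-out while the rest of the core stays the same. The two groups match in heavy atom count, in their six-membered aromatic ring of carbon only, and in their counts of hydrogen-bond donors and acceptors, so these counts do not separate them; no measurement at hand accounts for the step.

The exchange alters both the substituent on the phenyl ring and where it stands, so the compounds shown cannot say which of the two matters. A 4-methoxyphenyl or a 2-cyanophenyl group at the same position would pull these apart, and a 2-aminophenyl group would show whether the 2-position accepts a substituent other than methoxy.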